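Small Change at the Benzyl Group of a Receptor Binder

The source may report more compounds than this note shows. Statements on the series, on what has been measured and on what is new or still open speak of the compounds shown alone.

The measured compounds and their values in an assay on cells for displacement of a labelled ligand from corticotropin-releasing factor receptor 1 (Homo sapiens), with a stated time of 100 min; a lower number here means a stronger inhibitor, a higher number a weaker inhibitor:
compound 1 `CCCN(CCC(F)(F)F)Cc1c(C(F)(F)F)nc2n(-c3c(C)cc(C)cc3C)c(Cl)cn12` gives 12 nM;
compound 2 `Cc1cc(C)c(-n2c(Cl)cn3c(CN(CCC4CC4)CCC(F)(F)F)c(C(F)(F)F)nc23)c(C)c1` gives 110 nM;
compound 3 `Cc1cc(C)c(-n2c(Cl)cn3c(CN(CCC(F)(F)F)Cc4ccccc4)c(C(F)(F)F)nc23)c(C)c1` gives 43 nM.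

Compound 3 stands second highest of the three numbers: the step of a 2.6-fold lower number from compound 2 to compound 3 (0.41 log units; beyond the scatter) and the step of a 3.6-fold higher number from compound 1 to compound 3 (0.55 log units; beyond the scatter) place it between the other two. Compound 4 `Cc1cc(C)c(-n2c(Cl)cn3c(CN(CCC(F)(F)F)Cc4cccc(F)c4)c(C(F)(F)F)nc23)c(C)c1` keeps everything of compound 3 and differs only in one spot: fluoro in place of hydrogen on an aromatic carbon. Among the compounds with values here, none of the measured steps touches this spot; the steps of a 9.2-fold higher number from compound 1 to compound 2 (0.96 log units; beyond the scatter) and a 3.6-fold higher number from compound 1 to compound 3 (0.55 log units; beyond the scatter) alter the group on the amine nitrogen itself, not a substituent on the phenyl ring. Within the data shown here, with no direct precedent, a small step for compound 4 in this assay is expected, near the scatter, written as a 1.1-fold lower number from compound 3 to compound 4 (0.03 log units; within the scatter). Compound 4 is therefore estimated at 40 nM, within 15 nM to 120 nM.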

Compound 4, inhibition constant: 49 nM
Compound 4: middle estimate off by 1.2-fold (0.09 log units), on the low side; measured number inside the range.
By their numbers in this assay, from the lowest: compound 1; then compounds 3 and 4 (each within the scatter of the next); then compound 2.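

In this assay, compound 3 and compound 4 cannot be told apart (a 1.1-fold higher number from compound 3 to compound 4 (0.06 log units; within the scatter)), so a fluoro on this aromatic carbon, meta to a large group, is tolerated in this series. The 3-fluorobenzyl group also keeps the place of the benzyl group, with compound 4 still separated from the other two (a 2.2-fold lower number from compound 2 to compound 4 (0.35 log units; beyond the scatter); a 4.1-fold higher number from compound 1 to compound 4 (0.61 log units; beyond the scatter)). No measured evidence is available to explain this result.

From the compounds shown here alone, a larger group at this spot, such as methoxy or trifluoromethyl, remains open. So does an amine on the phenyl ring.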